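Methoxy substitution pattern on the pendant ring in the naphthol pyrazoline series

The source may hold more compounds than are shown below. What is called first, only, known or untested is meant among the compounds shown, and "the series" means these compounds.

Three analogues share one core and differ only in the methoxy pattern of the pendant ring. In a functional assay on HCT-116 cells (Homo sapiens) for cytotoxicity, read by crystal violet staining and colony formation, with a stated time of 7 days (a higher number here means a weaker inhibitor, a lower number a stronger inhibitor), compound 1 `COc1cccc(C2CC(c3ccc4ccccc4c3O)=NN2)c1OC` gives 15200 nM, compound 2 `COc1cccc(C2CC(c3ccc4ccccc4c3O)=NN2)c1` gives 20800 nM, and compound 3 `COc1ccc(C2CC(c3ccc4ccccc4c3O)=NN2)c(OC)c1` gives 8800 nM. Compound 1 and compound 2 differ by one change, (methoxy in place of hydrogen on an aromatic carbon), and this gives a 1.4-fold lower number from compound 2 to compound 1 (0.14 log units; within the scatter). The difference between the cores of compound 2 and compound 3 is not broken down here; their values in this assay simply lie as given.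

Compound 4 `COc1cc(OC)c(C2CC(c3ccc4ccccc4c3O)=NN2)c(OC)c1` is not yet measured. It differs from compound 3 by methoxy in place of hydrogen on an aromatic carbon, the same kind of change as from compound 2 to compound 1, though the place is not the same: there the new methoxy sits ortho to a methoxy group, here meta to two methoxy groups. Because the measured instance gave a 1.4-fold lower number from compound 2 to compound 1 (0.14 log units; within the scatter), a step of similar size is expected, a 1.3-fold lower number from compound 3 to compound 4 (0.10 log units; within the scatter). Compound 4 is therefore estimated at 7000 nM in this assay, plausibly between 3000 nM and 18000 nM.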

Compound 4, half-maximal inhibitory concentration: 32500 nM
Compound 4: the middle estimate sits 4.6-fold (0.67 log units) below what was measured, and the stated range ends below it.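

In this assay, methoxy in place of hydrogen on an aromatic carbon gives a 3.7-fold higher number from compound 3 to compound 4 (0.57 log units; beyond the scatter), so this change does not carry over as one fixed step from one core to the other: the same change on two cores in this assay, a 1.4-fold lower number (0.14 log units; within the scatter) from compound 2 to compound 1 and a 3.7-fold higher number (0.57 log units; beyond the scatter) from compound 3 to compound 4, 5.1-fold (0.70 log units) apart, beyond the scatter of two such steps

In compound 4 the new methoxy sits ortho to a large group and meta to two methoxy groups. The two steps differ in place as well as in core, so they do not separate the effect of place from that of core, and two steps give no rule for other cores in the series.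

Open, on these data alone, is how a hydroxy group, an amine or an ethoxy group would behave in the place of the new methoxy on compound 4. Also open, as far as these compounds go, is whether a single methoxy in that place would give a step like a 3.7-fold higher number from compound 3 to compound 4 (0.57 log units; beyond the scatter).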